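The source may hold more compounds than are shown below. What is called first, only, known or untested is meant among the compounds shown, and "the series" means these compounds.

Measured compounds:
Compound 1, `CCOc1cccnc1Nc1ccccn1`, in an assay on Ltk cells with metabotropic glutamate receptor 5 (Homo sapiens) as the target, read by fluorescence and calcium flux (a lower number here means a stronger inhibitor, a higher number a weaker inhibitor), compound 1 gives 138 nM.
Compound 2, `COc1cccnc1Nc1cccc(C)n1`, in this assay compound 2 gives 458 nM.
Compound 3, `CCOc1cc(C#N)cnc1Nc1cccc(C)n1`, in this assay compound 3 gives 46 nM.

Compound 3 holds the lowest of the three numbers. Its nearest neighbour is compound 1, whose number is higher by a margin that lies beyond the scatter of repeated measurements; compound 2 stands further away still, also beyond the scatter. Compound 3 is therefore the strongest inhibitor among these three, and it serves as the starting point for the next step.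

Compound 4, `CCOc1cc(-c2ccc(C)cc2)cnc1Nc1cccc(C)n1`, has not yet been measured in this assay. It differs from compound 3 in one place only: 4-methylphenyl in place of cyano on an aromatic carbon. The new group sits two atoms from the ring nitrogen, where the cyano stood before. Among the compounds with values here, no pair among the measured compounds shows a change of this kind, so there is no earlier step to lean on, and the direction of the effect is open. On the numbers available, compound 4 is expected to land near compound 3 or somewhat above it, with the change a 3.3-fold higher number from compound 3 to compound 4 (0.51 log units; beyond the scatter) taken as the expected step. For compound 4 the estimated value in this assay is 150 nM, within a range from 30 nM to 800 nM.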

Compound 4, half-maximal inhibitory concentration: 513 nM
Compound 4: middle estimate off by 3.4-fold (0.53 log units), on the low side, and the stated range covers the measured number.
By their numbers in this assay, from the lowest: compound 3; then compound 1; then compounds 2 and 4 (each within the scatter of the next).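

The carbon two atoms from the ring nitrogen, meta to the ethoxy group, proves sensitive to what it carries: in this assay, 4-methylphenyl in place of cyano gives an 11-fold higher number from compound 3 to compound 4 (1.05 log units; beyond the scatter), a large step beyond the scatter. This is the first change among these compounds that can be read in one place alone, and it shows that this position does not accept every group equally, since a group of 7 heavy atoms with an aromatic ring of carbon only gives a much weaker inhibitor here than the cyano group of 2 heavy atoms. No measurement bears on the reason for this loss, so the step stands as an observation without an explanation.

The compounds shown leave open whether the loss follows from the aromatic ring itself or from its methyl group, a question that plain phenyl at the same carbon would address. They also leave open how hydrogen, chlorine, methyl or a small amide at this carbon would compare with cyano, and so whether cyano is special here or the 4-methylphenyl group is simply poorly accepted.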